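From Bromo to Fluoro in an Antiproliferative Series

The source may report more compounds than this note shows. Statements on the series, on what has been measured and on what is new or still open speak of the compounds shown alone.

In a functional assay on MCF7 cells (Homo sapiens) for antiproliferative activity, read by MTT assay, with a stated time of 72 h (on this read-out higher numbers stand for weaker inhibition and lower numbers for stronger inhibition), the measured compounds read as follows:
compound 1 (`O=C(N/N=C/c1ccc(F)cc1)Nc1ccc(Oc2ccnc3[nH]ccc23)c(F)c1`) reads 800 nM
compound 2 (`O=C(N/N=C/c1ccccc1)Nc1ccc(Oc2ccnc3[nH]ccc23)cc1`) reads 1510 nM
compound 3 (`O=C(N/N=C/c1ccc(Br)cc1)Nc1ccc(Oc2ccnc3[nH]ccc23)cc1`) reads "not active" (no number reported)

Compound 3 has no single number in this assay and is reported only as ("not active" (no number reported)). Compound 4 (`O=C(N/N=C/c1ccc(F)cc1)Nc1ccc(Oc2ccnc3[nH]ccc23)cc1`) carries one change (fluoro in place of bromo on an aromatic carbon), with fluoro in place of bromo on an aromatic carbon, so that 4-bromophenyl becomes 4-fluorophenyl.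

Compound 1 also carries the 4-fluorophenyl group and reads 800 nM, while compound 2 reads 1510 nM, and these two values lie within the usual scatter of each other. A step in this assay is therefore expected toward stronger inhibition, from no reported number to a measurable one. Its size cannot be stated, as compound 3 has no number. A second report of no activity remains possible. For compound 4 the expected value is 1100 nM, with an estimated range from 400 nM to 3500 nM.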

Compound 4, half-maximal inhibitory concentration: 3720 nM
For compound 4 the middle estimate is 3.4-fold (0.53 log units) below the measured one; measured number outside the range, above it.
By their numbers in this assay, from the lowest: compounds 1 and 2 (each within the scatter of the next); then compound 4.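

In this assay, compound 3 has no number, so the step to compound 4 cannot be read, but the 4-fluorophenyl group does give a measurable reading at this position where the 4-bromophenyl group gave none. That reading is no gain over the unsubstituted phenyl, since fluoro in place of hydrogen here gives a 2.5-fold higher number from compound 2 to compound 4 (0.39 log units; beyond the scatter) in this series. The fluoro at this position also does not settle the reading alone: removing the other fluoro of compound 1, which lies elsewhere on the shared core, gives a 4.7-fold higher number from compound 1 to compound 4 (0.67 log units; beyond the scatter) while the 4-fluorophenyl group stays in place.

As far as these compounds go, whether chloro, methoxy or an amine at this position would read closer to hydrogen or to fluoro remains open. What lies behind these differences also remains open, as no further data bear on them.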